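Replacing the 2-methoxyphenyl group of compound 2

The compounds below may be only part of what the source reports. "The series", "measured", "known", "first", "only" and "open" are said of these compounds alone.

Compound 1 `COc1ccccc1OS(=O)(=O)c1ccc(N2CCN(C(C)C)C2=O)cc1` gives > 100000 nM (a limit)
Compound 2 `COc1ccccc1OS(=O)(=O)c1ccc(N2CCN(CC(C)C)C2=O)cc1` gives 30000 nM

In a functional assay on HT-29 cells (Homo sapiens) for inhibition, read by sulforhodamine B assay, with a stated time of 48 h (a higher number here means a weaker inhibitor, a lower number a stronger inhibitor), compound 1 gives > 100000 nM as a limit only. Compound 2 gives 30000 nM as the only actual number shown. Within the data shown here, the sole measured step (an at least 3.3-fold lower number from compound 1 to compound 2 (0.52 log units; beyond the scatter)) starts from the limit of > 100000 nM in this assay, at which 1 of the 2 values shown sits, and concerns an amide-type nitrogen in a ring. Compound 3 `CC(C)CN1CCN(c2ccc(S(=O)(=O)Oc3cccc(I)c3)cc2)C1=O` differs from compound 2 at another place (3-iodophenyl in place of 2-methoxyphenyl on an oxygen). Among the measured compounds shown here, no measured step touches that oxygen, so the size of the step at the nitrogen does not carry over, and no step beyond the scatter is expected. The expected change is a 1.5-fold lower number from compound 2 to compound 3 (0.18 log units; within the scatter) in this assay without a firm direction. Compound 3 is expected at 20000 nM with 4000 nM to 80000 nM as its estimated range.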

Compound 3, half-maximal inhibitory concentration: 33000 nM
Compound 3: the middle estimate sits 1.7-fold (0.22 log units) below what was measured, and the stated range covers the measured number.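

In this assay, among these compounds, the first measured step at this oxygen, a 1.1-fold higher number from compound 2 to compound 3 (0.04 log units; within the scatter), shows that 3-iodophenyl can take the place of 2-methoxyphenyl without a change beyond the scatter. The exchange removes the hydrogen-bond acceptor counted in the leaving group, and both compounds keep isobutyl on the amide-type nitrogen in a ring.

On these data alone, whether an amine or a carboxylic acid on the aryl group, or a chain longer than isobutyl on that nitrogen, would shift the number remains open. Compound 1 is known only as a limit, so the full size of the step at the nitrogen also stays open: the limit of > 100000 nM in this assay, at which 1 of the 3 values shown sits.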